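Thiazolidinone-triazole dithiocarbamates: cytotoxicity notes

A few compounds are considered here, and "the series" means these few. Any claim that something is new, unique, unknown or untested is made for them only; others in the source may bear on it.

Measured compounds:
Compound 1 `Cc1ccc(/C=C2\CN(C(=S)SCc3cn(Cc4ccc(F)cc4)nn3)C/C(=C\c3ccc(C)cc3)C2=O)cc1`: 45600 nM
Compound 2 `Cc1ccc(/C=C2\CN(C(=S)SCc3cn(Cc4ccccc4F)nn3)C/C(=C\c3ccc(C)cc3)C2=O)cc1`: 91500 nM
Compound 3 `O=C1/C(=C/c2ccccc2F)CN(C(=S)SCc2cn(Cc3ccccc3F)nn2)C/C1=C\c1ccccc1F`: 57600 nM

All three were read in a functional assay on MDA-MB-231 cells (Homo sapiens) for cytotoxicity, read by MTT assay, with a stated time of 24 h; on this read-out higher numbers stand for weaker inhibition and lower numbers for stronger inhibition. Compound 1 and compound 2 share a core and differ by 4-fluorophenyl in place of 2-fluorophenyl on a saturated chain carbon bound to an aromatic nitrogen; the step of a 2.0-fold lower number from compound 2 to compound 1 (0.30 log units; within the scatter). Compound 3 carries a different core; how its core differs from that of compound 2 is not broken down here. Compound 4 `O=C1/C(=C/c2ccccc2F)CN(C(=S)SCc2cn(Cc3ccc(F)cc3)nn2)C/C1=C\c1ccccc1F` is not yet measured and relates to compound 3 by 4-fluorophenyl in place of 2-fluorophenyl on a saturated chain carbon bound to an aromatic nitrogen, the same kind of change as that from compound 2 to compound 1. Given that the earlier step stayed within the scatter, the step from compound 3 to compound 4 is expected to be small as well, estimated at a 1.4-fold lower number from compound 3 to compound 4 (0.16 log units; within the scatter). Compound 4 is therefore expected near 40000 nM, likely between 15000 nM and 110000 nM.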

Compound 4, half-maximal inhibitory concentration: 58800 nM
For compound 4 the middle estimate is 1.5-fold (0.17 log units) below the measured one; measured number inside the range.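

In this assay the change from 2-fluorophenyl to 4-fluorophenyl on a saturated chain carbon bound to an aromatic nitrogen gives a 1.0-fold higher number from compound 3 to compound 4 (0.01 log units; within the scatter) on the second core. Set side by side, the two steps do not separate the cores, so the change carries across them without a step beyond the scatter: the same change on two cores in this assay, a 2.0-fold lower number (0.30 log units; within the scatter) from compound 2 to compound 1 and a 1.0-fold higher number (0.01 log units; within the scatter) from compound 3 to compound 4, 2.0-fold (0.31 log units) apart, within the scatter of two such steps

Going by these compounds alone, this rests on only two pairs, with every step within the scatter, so it establishes neither a real effect of the change on either core nor the same behaviour on further cores. The compounds shown leave open how the read-out responds when an amine or a carboxylic acid takes the place of the fluorine, or when a longer chain replaces the fluorobenzyl group.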